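The source may hold more compounds than are shown below. What is called first, only, known or untested is meant among the compounds shown, and "the series" means these compounds.

Compound 1 `Nc1scc(CN2CCN(c3ccc(Cl)cc3Cl)CC2)c1C(=O)c1ccc(Cl)cc1`: 0%
Compound 2 `Nc1scc(CN2CCN(c3ccc([N+](=O)[O-])cc3)CC2)c1C(=O)c1ccc(Cl)cc1`: 1%
Compound 3 `Nc1scc(CN2CCN(c3cccc4ccccc34)CC2)c1C(=O)c1ccc(Cl)cc1`: 1%

In an assay on CHO cells for displacement of a labelled ligand from adenosine receptor A1 (Homo sapiens), read by scintillation counting, with a stated time of 120 min, tested at 10 uM (a lower number here means less inhibition, a higher number more inhibition at the concentration tested (going by the name of the read-out)), compound 1 gives 0%, the lowest of the three numbers, though the others sit within the scatter of it. Compound 4 `Nc1scc(CN2CCN(c3cc(F)ccc3F)CC2)c1C(=O)c1ccc(Cl)cc1` differs from compound 1 in one place: 2,5-difluorophenyl in place of 2,4-dichlorophenyl on an amine nitrogen in a ring. The measured steps that bear on this are the ones swapping the same aryl group on the ring nitrogen: a number 1 percentage points higher from compound 1 to compound 2 (within the scatter) and a number 1 percentage points higher from compound 1 to compound 3 (within the scatter), both within the scatter, and no change at the digits printed from compound 2 to compound 3 (within the scatter). None of these aryl exchanges moved the read-out beyond the scatter, so no step beyond the scatter is expected in this assay either. Compound 4 is therefore estimated at 1%, between 0% and 8%, which means an expected step of a number 1 percentage points higher from compound 1 to compound 4 (within the scatter).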

Compound 4, a percentage reported as inhibition, at one concentration (the size of the read-out at that concentration, not a potency): 1%
Estimate against measurement, compound 4: no gap at the digits printed; the range from low to high includes it.
By their numbers in this assay, from the lowest: compounds 1, 2, 3 and 4 (each within the scatter of the next).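

In this assay the 2,5-difluorophenyl group on the ring nitrogen joins the other aryl groups with no separation from them: the read-out shows a number 1 percentage points higher from compound 1 to compound 4 (within the scatter) and no change at the digits printed from compound 3 to compound 4 (within the scatter) and also no change at the digits printed from compound 2 to compound 4 (within the scatter) in this series. Fluorine-bearing, chlorine-bearing, nitro-bearing and naphthalen-1-yl groups at this position therefore all give values within the scatter of each other. No measured evidence accounts for this flat result. Still open, from the compounds shown here alone, is whether an aryl group carrying an amine or a carboxylic acid, or a benzyl group on this nitrogen, would give a read-out beyond the scatter.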